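This account rests on a few compounds, and the source may have more. Where it says the series, first, only, none or still open, it means among the compounds named here.

Measured in a functional assay on HeLa cells (Homo sapiens) for inhibition, read by MTT assay, with a stated time of 72 h; a lower number here means a stronger inhibitor, a higher number a weaker inhibitor:
compound 1 `Nc1nc2cc(-c3nn(CCCCCCCCCC(=O)NO)c4ncnc(N)c34)ccc2o1`: > 50000 nM
compound 2 `Nc1ncnc2c1c(-c1cnc3[nH]ccc3c1)nn2CCCCCCC(=O)NO`: 22000 nM
compound 3 `Nc1nc2cc(-c3nn(CCCCCCCCC(=O)NO)c4ncnc(N)c34)ccc2o1`: 10200 nM

Compound 1 gives only a limit and not a number, > 50000 nM. Of the two actual numbers, compound 3 has the lower at 10200 nM, and compound 2 the higher at 22000 nM, a gap beyond the scatter.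

Compound 4 `Nc1nc2cc(-c3nn(CCCCCCC(=O)NO)c4ncnc(N)c34)ccc2o1` has not yet been measured. It differs from compound 3 on a saturated chain carbon, six bonds along the chain from an aromatic nitrogen, where hydroxycarbamoyl stands in place of 2-(hydroxycarbamoyl)ethyl: hydroxycarbamoyl in place of 2-(hydroxycarbamoyl)ethyl on a saturated chain carbon, six bonds along the chain from an aromatic nitrogen.

Among the compounds with values here, one measured step bears on this change: an at least 4.9-fold lower number from compound 1 to compound 3 (0.69 log units; beyond the scatter). There, hydroxycarbamoyl replaced (hydroxycarbamoyl)methyl, a change of the same kind but smaller. Its size is open on one side and it is a single step, so it suggests a direction but no rate per chain unit. Within the data shown here, nothing measured so far in this assay shows whether the trend continues, so the expectation is a modest move towards a lower number, with a wide margin. The expected change is a 2.0-fold lower number from compound 3 to compound 4 (0.31 log units; beyond the scatter). For compound 4 the estimate is 5000 nM, with an expected range of 1200 nM to 20000 nM.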

Compound 4, half-maximal inhibitory concentration: 6410 nM
Compound 4: middle estimate off by 1.3-fold (0.11 log units), on the low side; low and high end bracket the measured number.
By their numbers in this assay, from the lowest: compounds 4 and 3 (each within the scatter of the next); then compound 2. At a limit, above all of these: compound 1.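

In this assay, the change from 2-(hydroxycarbamoyl)ethyl to hydroxycarbamoyl, on a saturated chain carbon, six bonds along the chain from an aromatic nitrogen, gives a 1.6-fold lower number from compound 3 to compound 4 (0.20 log units; within the scatter), so this shortening does not separate the two compounds, unlike the shortening at the longest chain. Over the wider span, hydroxycarbamoyl in place of 3-(hydroxycarbamoyl)propyl gives an at least 7.8-fold lower number from compound 1 to compound 4 (0.89 log units; beyond the scatter), a size open on one side since compound 1 stands only at a limit: the limit of > 50000 nM in this assay, at which 1 of the 4 values shown sits. With the chain held, exchanging the aromatic group on the shared core gives a 3.4-fold lower number from compound 2 to compound 4 (0.54 log units; beyond the scatter), the first measured sign in this series that this group, and not only the chain, moves the number.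

On these data alone, whether a still shorter chain would keep the number level or shift it stays open, as does whether a carboxylic acid or a primary amide could stand in place of the hydroxycarbamoyl end. The values shown all come from this assay, so they leave open how far these differences hold in any other cell line or in an assay on an isolated enzyme.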